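Aryl swap on the five-membered ring of compound 2

The compounds below may be only part of what the source reports. "The series", "measured", "known", "first", "only" and "open" are said of these compounds alone.

Measured so far:
compound 1, `CCSc1sc(-n2nc(C)c(Cc3ccccc3[N+](=O)[O-])c2C(=O)O)nc1-c1ccc(Cl)c(Cl)c1` — 59000 nM
compound 2, `Cc1nn(-c2nc(-c3ccc(Cl)c(Cl)c3)c(SC(C)C)s2)c(C(=O)O)c1-c1cncnc1` — 22000 nM

In a functional assay on BJAB cells (Homo sapiens) for antiproliferative activity, with a stated time of 4 days (on this read-out lower numbers stand for an effect already at smaller amounts and higher numbers for an effect only at larger amounts of compound), compound 1 gives 59000 nM. In this assay compound 2 gives 22000 nM, the lower of the two numbers, and its gap to compound 1 lies beyond the scatter. The two compounds differ in more than one place, so their values say nothing about any single change.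

Compound 3, `Cc1nn(-c2nc(-c3ccc(Cl)c(Cl)c3)c(SC(C)C)s2)c(C(=O)O)c1-c1ccccc1C(F)(F)F`, differs from compound 2 by 2-(trifluoromethyl)phenyl in place of pyrimidin-5-yl on an aromatic carbon. Within the data shown here, no measured pair isolates this exchange, and both measured values sit at the weak end of the read-out. The expected step for compound 3 in this assay is small and without a clear direction, and may stay within the scatter. The step that this expectation means is a 1.1-fold lower number from compound 2 to compound 3 (0.04 log units; within the scatter). Compound 3 is estimated at 20000 nM, within a range from 6000 nM to 70000 nM.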

Compound 3, half-maximal effective concentration: 5200 nM
Compound 3: middle estimate off by 3.8-fold (0.59 log units), on the high side, and the stated range ends above it.
By their numbers in this assay, from the lowest: compound 3; then compound 2; then compound 1.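

In this assay, 2-(trifluoromethyl)phenyl in place of pyrimidin-5-yl gives a 4.2-fold lower number from compound 2 to compound 3 (0.63 log units; beyond the scatter), so the number does respond to the aryl group at this position, next to the ring atom that bears a carboxy group. The change also shows that a ring of carbon only, with 0 hydrogen-bond acceptors, can stand here in place of a ring with 2 hetero atoms and give a lower number; compounds 1 and 2 could not show this, as they differ in more than one place. Nothing available explains this step.

Among these compounds, the single pair changes the ring atoms and adds the trifluoromethyl group at once, so the contribution of each remains unseparated. Open too, on these data alone, is how a plain phenyl ring, or the same ring carrying an amine, would read in this assay.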